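A quinolin-3-yl swap at a measurement limit

The compounds below may be only part of what the source reports. "The series", "measured", "known", "first", "only" and "open" are said of these compounds alone.

Three compounds share one core: compound 1 (`c1ccc(-c2nccnc2OC2CN(c3ccc4ccccc4n3)C2)cc1`), compound 2 (`Cc1ccc(-c2nccnc2OC2CN(c3ccc4ccccc4n3)C2)cc1`) and compound 3 (`N#Cc1ccc(-c2nccnc2OC2CN(c3ccc4ccccc4n3)C2)cc1`). In a physicochemical assay for solubility, in phosphate buffer, at pH 7.4 (on this read-out lower numbers stand for lower solubility and higher numbers for higher solubility), compound 1 gives < 1000 nM, which is a limit and not a number. In this assay compound 2 gives < 1000 nM, again a limit. Compound 3, the starting point here, gives < 1000 nM, also a limit. Compound 3 therefore has no exact place among the three, only a shared ceiling.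

Compound 4 (`c1ccc2ncc(-c3nccnc3OC3CN(c4ccc5ccccc5n4)C3)cc2c1`) changes one group: quinolin-3-yl in place of 4-cyanophenyl, on an aromatic carbon of a six-membered aromatic ring with 2 nitrogen (quinolin-3-yl in place of 4-cyanophenyl on an aromatic carbon). Among the compounds with values here, none of the measured compounds carries quinolin-3-yl, so the closest evidence comes from changes to the group that leaves. These are a step that the two limits leave unreadable from compound 1 to compound 3 and a step that the two limits leave unreadable from compound 2 to compound 3, and a step that the two limits leave unreadable from compound 1 to compound 2 adds nothing further, since none of the three has a readable size. What remains is the limit of < 1000 nM in this assay, at which 3 of the 3 values shown sit. On that basis, no step beyond the usual scatter is expected in either direction, and another limit is the most likely report. The expected change is a step that the limit leaves unreadable from compound 3 to compound 4. For compound 4 the estimated value is 500 nM, with an expected range from 200 nM to 1000 nM.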

Compound 4, solubility: < 1000 nM
Compound 4: a limit, no number (the forecaster's own chance of this, stated with the estimate: 85%); the middle value lies beyond the limit too.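

In this assay, compound 4 gives only a limit, as do compound 1, compound 2 and compound 3, so no step between any of them can be read: the limit of < 1000 nM in this assay, at which 4 of the 4 values shown sit.

Where these four compounds truly stand relative to one another, and whether swapping the group at this place shifts the read-out at all, remains open.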